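Shortening a Side Chain on a Shared Core

This account rests on a few compounds, and the source may have more. Where it says the series, first, only, none or still open, it means among the compounds named here.

Of the compounds shown here, two have so far been measured in a functional assay on NCI-H460 cells (Homo sapiens) for antiproliferative activity, read by CCK-8 assay, with a stated time of 72 h, tested at 8 uM; on this read-out higher numbers stand for a stronger effect at the one concentration tested and lower numbers for a weaker effect. Compound 1 `CC1CCN(c2nc(Cl)nc3c2ncn3Cc2ccc(/C=C/C(=O)Nc3ccccc3N)cc2)CC1` gives 10.8%, the lower of the two numbers; compound 2 `Nc1ccccc1NC(=O)/C=C/c1ccc(Cn2cnc3c(NC4CCCCC4)nc(Cl)nc32)cc1` gives 24.9%. The step of a number 14.1 percentage points higher from compound 1 to compound 2 (beyond the scatter) concerns a different place on the shared core. Compound 3 `CC1CCN(c2nc(Cl)nc3c2ncn3Cc2ccc(C(=O)Nc3ccccc3N)cc2)CC1` differs from compound 1 in one place: (2-aminophenyl)carbamoyl in place of 2-((2-aminophenyl)carbamoyl)ethenyl on an aromatic carbon. For the measured compounds named here, no measured step touches this part of the molecule, so the data give no direction for it. Compound 3 is therefore expected to give about 9%, within 0% to 22%. The step of a number 1.8 percentage points lower from compound 1 to compound 3 (within the scatter) that this estimate means is expected to stay within the scatter.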

Compound 3, a percentage reported as inhibition, at one concentration (the size of the read-out at that concentration, not a potency): 40.9%
Beside the measured number, compound 3's estimate is 31.9 percentage points below it; measured number above the stated range.
By their numbers in this assay, from the lowest: compound 1; then compound 2; then compound 3.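

In this assay, taking the ethenyl link out of the side chain, so that (2-aminophenyl)carbamoyl sits directly on the aromatic carbon, gives a number 30.1 percentage points higher from compound 1 to compound 3 (beyond the scatter). The side chain at this position therefore affects the read-out, which the earlier step, made elsewhere on the shared core, could not show. Nothing available explains why the shorter side chain gives the higher number.

Going by these compounds, it remains open whether cyclohexylamino on the core would combine with the shorter side chain to raise the number further. On these data alone, it is also open how a saturated ethylene chain would compare with either link.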